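The source may report more compounds than this note shows. Statements on the series, on what has been measured and on what is new or still open speak of the compounds shown alone.

Compounds measured in an ADME assay on microsomes from liver (Homo sapiens) for metabolic stability, with a stated time of 30 min; on this read-out lower numbers stand for a less stable compound and higher numbers for a more stable compound:
- compound 1, `CC(C)(C)OC(=O)N1CCC(CC(=O)Nc2nc3ccccc3o2)CC1`: 83%
- compound 2, `CC(C)(C)OC(=O)N1CCC(CC(=O)Nc2nc3cc(Cl)ccc3o2)CC1`: 43%
- compound 3, `Cc1ccc2nc(NC(=O)CC3CCN(C(=O)OC(C)(C)C)CC3)oc2c1`: "not determined" (no result reported)

Compound 1 stands highest of the two numbers in this assay; its nearest neighbour is compound 2, with a number 40 percentage points lower from compound 1 to compound 2 (beyond the scatter). Compound 4, `CC(=O)c1ccc(N2CCC(CC(=O)Nc3nc4ccccc4o3)CC2)cc1`, differs from compound 1 by 4-acetylphenyl in place of tert-butoxycarbonyl on an amine nitrogen in a ring. Within the data shown here, the single measured step, from compound 1 to compound 2, concerns a chloro on an aromatic carbon of the shared core, not the amine nitrogen in the ring, so no measured step bears directly on this change, and the direction of the expected step in this assay remains open. Compound 4 is estimated at 55%, within a range of 20% to 85%. This estimate means a step of a number 28 percentage points lower from compound 1 to compound 4 (beyond the scatter), expected rather than known.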

Compound 4, percent of the compound remaining: 62%
Estimate against measurement, compound 4: 7 percentage points below, and the stated range covers the measured number.
By their numbers in this assay, from the lowest: compound 2; then compound 4; then compound 1.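

In this assay, among these compounds, putting 4-acetylphenyl in place of tert-butoxycarbonyl on the amine nitrogen in the ring gives a number 21 percentage points lower from compound 1 to compound 4 (beyond the scatter) and offers the first measured look at this position. The read-out therefore responds to a change here, not only to the chloro on the aromatic carbon, yet a sizeable part of the stability remains with the new group. No measurement shown gives a reason for this step.

Because the whole group changes at once, the separate roles of the acetyl and the aromatic ring cannot be told apart. As far as these compounds go, how a plain phenyl or a small methyl on this nitrogen would read remains open.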